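Phenol versus methyl ether in the bis-trifluoromethyl urea series

This account rests on a few compounds, and the source may have more. Where it says the series, first, only, none or still open, it means among the compounds named here.

Within the data shown here, compound 2 `COc1cc(-c2nn(-c3cccc(NC(=O)Nc4cc(C(F)(F)F)cc(C(F)(F)F)c4)c3)cc2-c2ccncc2)ccc1Cl` gives 6560 nM in a functional assay on NCI-H522 cells (Homo sapiens) for inhibition, read by sulforhodamine B assay, with a stated time of 48 h (on this read-out lower numbers stand for higher toxicity in this test and higher numbers for lower toxicity in this test), and is the only plain number in the set. Compound 1 `O=C(Nc1cccc(-n2cc(-c3ccncc3)c(-c3ccc(Cl)c(O)c3)n2)c1)Nc1cccc(C(F)(F)F)c1` returns only a limit in this assay, > 32500 nM. Among the measured compounds shown here, compound 1 and compound 2 differ in two places, so no single measured step connects them. The remaining reading in hand is thus (the limit of > 32500 nM in this assay, at which 1 of the 2 values shown sits). Compound 3 `O=C(Nc1cccc(-n2cc(-c3ccncc3)c(-c3ccc(Cl)c(O)c3)n2)c1)Nc1cc(C(F)(F)F)cc(C(F)(F)F)c1` is not yet measured. It differs from compound 2 by hydrogen in place of methyl on an oxygen on an aromatic ring. For the measured compounds named here, no measured step of this kind exists, so the expected step of a 1.4-fold higher number from compound 2 to compound 3 (0.16 log units; within the scatter) is estimated as small, probably within scatter, with a slight lean toward lower toxicity in this test. Compound 3 is therefore expected near 9500 nM, with a range from 3200 nM to 32500 nM.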

Compound 3, concentration lethal to 50% of the cells: 12800 nM
Compound 3: the middle estimate sits 1.3-fold (0.13 log units) below what was measured; the range from low to high includes it.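

In this assay, the change from methoxy to hydroxy on the 4-chloro-3-methoxyphenyl group reads as a 2.0-fold higher number from compound 2 to compound 3 (0.29 log units; within the scatter), so swapping methyl for hydrogen on this oxygen cannot be told apart from repeat scatter in the bis-trifluoromethyl urea series. Among these compounds, with the hydroxy group held constant, trifluoromethyl in place of hydrogen on an aromatic carbon gives an at least 2.5-fold lower number from compound 1 to compound 3 (0.40 log units; beyond the scatter), which is the only step here beyond the scatter. Compound 1 is a limit and not a number, so this step gives a minimum size only: the limit of > 32500 nM in this assay, at which 1 of the 3 values shown sits.

Still open, going by these compounds, is whether the trifluoromethyl step keeps its size with methoxy in place of hydroxy. Also open, on these data alone, is how this read-out responds to an ethyl group or a longer chain on that oxygen, or to an amine in place of the hydroxy.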